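Acrylophenone thioethers: growth inhibition in DU-145 cells

A few compounds are considered here, and "the series" means these few. Any claim that something is new, unique, unknown or untested is made for them only; others in the source may bear on it.

Measured so far:
compound 1 `O=C(/C(=C\c1ccc(F)cc1F)Sc1ccc(Br)cc1)c1ccc(Br)cc1`, 1000 nM
compound 2 `COc1ccc(C(=O)/C(=C\c2ccc(O)c([N+](=O)[O-])c2)SCc2ccc(Br)cc2)cc1`, 10000 nM
compound 3 `O=C(O)c1ccc(C(=O)/C(=C\c2ccc(Cl)c([N+](=O)[O-])c2)SCc2ccc(Cl)cc2)cc1`, 1000 nM

The three compounds share a core carrying an aryl ketone, a thioether and a benzylidene arm, and were tested in a functional assay on DU-145 cells (Homo sapiens) for inhibition, read by trypan blue exclusion, with a stated time of 96 h; on this read-out lower numbers stand for stronger inhibition of growth and higher numbers for weaker inhibition of growth. Compound 1 gives 1000 nM and compound 3 gives 1000 nM; these two numbers lie within the scatter of each other, so no order between them is drawn. Compound 2 gives 10000 nM, the highest number of the three, and its gap to compound 1 and to compound 3 is beyond the scatter in each case, so compound 2 is the weakest of the measured set.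

Compound 4 `O=C(/C(=C\c1ccc(O)c([N+](=O)[O-])c1)SCc1ccc(Br)cc1)c1ccc(O)cc1O` is not yet measured. It differs from compound 2 in one place: 2,4-dihydroxyphenyl in place of 4-methoxyphenyl on a carbonyl carbon. Among the compounds with values here, no measured pair in the set differs in this position alone, so no step of this kind is known here. The expectation is a small step, not clearly beyond the scatter, with the direction open; a modest move toward a lower number is taken as the middle case. For compound 4 in this assay the estimate is 5000 nM, within 1500 nM to 20000 nM, which means an expected step of a 2.0-fold lower number from compound 2 to compound 4 (0.30 log units; within the scatter).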

Compound 4, concentration for 50% growth inhibition: > 100000 nM
Compound 4: only a limit was reported; the forecaster's own chance of this, stated with the estimate: 15%; middle value at least 20-fold (1.30 log units) from the limit.
By their numbers in this assay, from the lowest: compounds 1 and 3 (each within the scatter of the next); then compound 2. At a limit, above all of these: compound 4.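

In this assay, within the data shown here, the aryl group on a carbonyl carbon proves able to carry a large change on its own: 2,4-dihydroxyphenyl in place of 4-methoxyphenyl gives an at least 10-fold higher number from compound 2 to compound 4 (1.00 log units; beyond the scatter), the first single-place step, with the thioether and the benzylidene arm held fixed. Compound 4 stands at a limit and not at a number, so the step has only a floor: the limit of > 100000 nM in this assay, at which 1 of the 4 values shown sits. Both groups have 8 heavy atoms and one six-membered aromatic ring, while the count moves from 0 to 2 hydrogen-bond donors, so this loss of growth inhibition comes with an exchange of ring substituents and not with a change in the size of the group.

The compounds shown do not separate the removal of the methoxy group from the addition of either hydroxyl, and they do not tell whether the same step holds with other thioether or benzylidene arms. Also open, from the compounds shown here alone, is how an amine on this ring, or a longer chain in place of the ring on the carbonyl carbon, would read in this assay.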